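Benzyl to benzoyl on the bromophenol oxygen

A few compounds are considered here, and "the series" means these few. Any claim that something is new, unique, unknown or untested is made for them only; others in the source may bear on it.

Measured in an ADME assay on BAEC cells (Bos taurus) for cytotoxicity, read by MTT assay, with a stated time of 2 days; a higher number here means a weaker inhibitor, a lower number a stronger inhibitor:
- Compound 1 `COc1c(Br)cc(CO)c(OCCO)c1Br`: > 28000 nM (a limit)
- Compound 2 `COc1c(Br)cc(/C=C2\N=C(c3ccccc3)OC2=O)c(OCc2ccccc2)c1Br`: 921000 nM

Among the measured compounds shown here, compound 2 holds the only actual number, since the other entry is a limit: the limit of > 28000 nM in this assay, at which 1 of the 2 values shown sits. Compound 3 `COc1c(Br)cc(/C=C2\N=C(c3ccccc3)OC2=O)c(OC(=O)c2ccccc2)c1Br` has benzoyl in place of benzyl on an oxygen on an aromatic ring. For the measured compounds named here, no measured step covers this change. With compound 2 at 921000 nM, a modest move toward a lower number is expected in this assay. The estimated step is a 2.3-fold lower number from compound 2 to compound 3 (0.36 log units; beyond the scatter). For compound 3 the expected value is 400000 nM. The estimated range runs from 80000 nM to 1200000 nM.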

Compound 3, half-maximal inhibitory concentration: > 18000 nM
Compound 3 gave a limit, no number (the forecaster's own chance of this, stated with the estimate: 20%); the middle value lies beyond the limit too.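

Compound 3 returns only a limit in this assay, so the change from compound 2 to compound 3 cannot be read as a step. As far as these compounds go, whether benzoyl in place of benzyl on an oxygen on an aromatic ring shifts this number, and in which direction, stays open.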